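The compounds below may be only part of what the source reports. "The series", "measured", "known", "first", "only" and "open" are said of these compounds alone.

Measured so far in a functional assay on CFPAC-1 cells (Homo sapiens) for antiproliferative activity, read by MTT assay, with a stated time of 72 h; a lower number here means a stronger inhibitor, a higher number a weaker inhibitor: compound 1 `CCCCCCCCCCc1cn(C[C@H](O)[C@H]2OC(=O)C(OCc3ccccc3)=C2OCc2ccccc2)nn1` gives 40300 nM. Compound 3 `O=C1O[C@H]([C@@H](O)Cn2cc(-c3cc(F)cc(F)c3)nn2)C(OCc2ccccc2)=C1OCc1ccccc1` gives 62400 nM. Compound 2 `Cc1ccc(-c2cn(C[C@H](O)[C@H]3OC(=O)C(OCc4ccccc4)=C3OCc3ccccc3)nn2)cc1` reaches only > 100000 nM, which is a limit of the assay and not a number.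

Of the two numbers, compound 3 holds the higher one, yet its gap to compound 1 is within the scatter, as a 1.5-fold higher number from compound 1 to compound 3 (0.19 log units; within the scatter) shows. Compound 4 `COc1ccc(-c2cn(C[C@H](O)[C@H]3OC(=O)C(OCc4ccccc4)=C3OCc3ccccc3)nn2)cc1` differs from compound 3 by 4-methoxyphenyl in place of 3,5-difluorophenyl on an aromatic carbon. Among the measured compounds shown here, the steps that bear on this change are those swapping one aryl group for another on the same carbon: an at least 2.4-fold higher number from compound 1 to compound 2 (0.39 log units; beyond the scatter) and an at least 1.6-fold lower number from compound 2 to compound 3 (0.20 log units; that floor lies within the scatter). Compound 2, the 4-methylphenyl analogue, sits at the limit of > 100000 nM in this assay, at which 1 of the 3 values shown sits. The 4-methoxyphenyl group resembles the 4-methylphenyl group of compound 2 more than the 3,5-difluorophenyl group of compound 3, so a modest weakening is expected in this assay, a 1.4-fold higher number from compound 3 to compound 4 (0.16 log units; within the scatter). Compound 4 is therefore estimated at 90000 nM, within a range from 40000 nM to 200000 nM, with a real chance that only a limit is reported.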

Compound 4, half-maximal inhibitory concentration: 26000 nM
Estimate against measurement, compound 4: 3.5-fold (0.54 log units) above; the measured number lies below the stated range.
By their numbers in this assay, from the lowest: compounds 4, 1 and 3 (each within the scatter of the next, the first and the last beyond it). At a limit, above all of these: compound 2.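

In this assay, a single group on the phenyl ring matters at this carbon of the five-membered aromatic ring: 4-methoxyphenyl in place of 3,5-difluorophenyl gives a 2.4-fold lower number from compound 3 to compound 4 (0.38 log units; beyond the scatter), and methoxy in place of methyl gives an at least 3.8-fold lower number from compound 2 to compound 4 (0.58 log units; beyond the scatter). An aryl group here can also stand level with the decyl chain, as 4-methoxyphenyl in place of decyl gives only a 1.6-fold lower number from compound 1 to compound 4 (0.19 log units; within the scatter). The step from the 4-methylphenyl analogue has only a floor, and compound 2 remains at a limit: the limit of > 100000 nM in this assay, at which 1 of the 4 values shown sits.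

As far as these compounds go, how a hydroxy, ethoxy or dimethylamino group on that phenyl ring would compare with methoxy remains open. From the compounds shown here alone, the true size of the change from methyl to methoxy also remains open.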